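Methoxy to methyl on the aromatic carbon of compound 2

This account rests on a few compounds, and the source may have more. Where it says the series, first, only, none or still open, it means among the compounds named here.

Values in an in vitro assay on cells for inhibition of Amine oxidase [flavin-containing] A (Homo sapiens), read by Amplex Red, with a stated time of 15 min, tested at 100 uM; a higher number here means more inhibition at the concentration tested (going by the name of the read-out), a lower number less inhibition:
compound 1 `CC1CN(C(N)=S)N=C1c1ccc(F)cc1`: 40%
compound 2 `COc1ccc(C2=NN(C(N)=S)CC2C)cc1`: 40%

Compound 2 stands level with compound 1 at the digits given: the step of no change at the digits printed from compound 1 to compound 2 (within the scatter) lies within the scatter of this assay. The unmeasured compound 3 `Cc1ccc(C2=NN(C(N)=S)CC2C)cc1` differs from compound 2 by methyl in place of methoxy on an aromatic carbon.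

Among the measured compounds shown here, the only measured step that bears on this change is the one at the same aromatic carbon, where methoxy replaced fluoro, no change at the digits printed from compound 1 to compound 2 (within the scatter), which produced no change beyond the scatter. Two different substituents at that carbon gave the same reading, so no step beyond the scatter is expected for methyl at that position either; the expected step is no change at the digits printed from compound 2 to compound 3 (within the scatter). Compound 3 is therefore estimated at 40% in this assay, with a range from 25% to 55%.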

Compound 3, a percentage reported as inhibition, at one concentration (the size of the read-out at that concentration, not a potency): "not active" (no number reported)
The entry for compound 3 holds no number; no gap can be computed for the estimate.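

In this assay, among the compounds shown here, compound 3 is entered as "not active" (no number reported) and carries no number, so no step from compound 2 to compound 3 can be read. The compounds shown leave open how far methyl in place of methoxy shifts inhibition. No supporting data bear on this result.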